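The compounds below may be only part of what the source reports. "The series", "measured", "known", "first", "only" and "open" are said of these compounds alone.

Measured so far in a functional assay on RS4-11 cells (Homo sapiens) for inhibition, read by CCK-8 assay, with a stated time of 48 h, tested at 20 uM; a lower number here means less inhibition of growth, a higher number more inhibition of growth at the concentration tested:

Compound 1 `COc1ccc(Cc2nnc(NC(=O)/C(C#N)=C/c3ccccc3OS(=O)(=O)c3ccc([N+](=O)[O-])cc3)s2)cc1` gives 70%
Compound 2 `N#C/C(=C\c1ccccc1OS(=O)(=O)c1ccc([N+](=O)[O-])cc1)C(=O)Nc1nnc(Cc2ccccc2)s1` gives 57%
Compound 3 `Cc1ccc(S(=O)(=O)Oc2ccccc2/C=C(\C#N)C(=O)Nc2nnc(Cc3ccc(F)cc3)s2)cc1` gives 72%

Compound 3 at 72% sits level with compound 1, within the scatter, and clearly higher than compound 2. The next compound, compound 4 `N#C/C(=C\c1ccccc1OS(=O)(=O)c1ccc([N+](=O)[O-])cc1)C(=O)Nc1nnc(Cc2ccc(F)cc2)s1`, differs from compound 3 in one place, with nitro in place of methyl on an aromatic carbon, para to a large group: nitro in place of methyl on an aromatic carbon.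

Among the compounds with values here, no measured pair shows this exact change. Within the data shown here, the only measured step, a number 13 percentage points lower from compound 1 to compound 2 (beyond the scatter), is a different change, hydrogen in place of methoxy on an aromatic carbon, so it shows only how far one swap has moved the number here. Nitro itself is already present in two compounds: compound 1 gives 70%, and compound 2 gives 57%. With that evidence, a small drop at most is expected in this assay, and no step beyond the scatter.

The estimated step is a number 4 percentage points lower from compound 3 to compound 4 (within the scatter). For compound 4 the estimated value is 68%, with an expected range from 52% to 82%.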

Compound 4, percent growth inhibition at one concentration: 55%
For compound 4 the middle estimate is 13 percentage points above the measured one; the measured number falls inside the stated range.
By their numbers in this assay, from the lowest: compounds 4 and 2 (each within the scatter of the next); then compounds 1 and 3 (each within the scatter of the next).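

In this assay, within the data shown here, the change from 4-methylphenyl to 4-nitrophenyl gives a number 17 percentage points lower from compound 3 to compound 4 (beyond the scatter) and so shows that the group at this position can move the number, which the earlier compounds could not show because none of them formed this pair. With the nitro group kept, fluoro in place of hydrogen gives a number 2 percentage points lower from compound 2 to compound 4 (within the scatter) while fluoro in place of methoxy gives a number 15 percentage points lower from compound 1 to compound 4 (beyond the scatter) so among the three nitro compounds only compound 1 stands apart. Nothing measured here offers a reason for these steps.

Still open, going by these compounds, is whether an amine or a carboxylic acid in this place would read like the nitro compound or like the methyl compound. Also open, on these data alone, is whether the methyl-to-nitro step keeps its size when methoxy or hydrogen replaces the fluoro.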